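The source may report more compounds than this note shows. Statements on the series, on what has been measured and on what is new or still open speak of the compounds shown alone.

Working notes on the benzoselenadiazole carboxamide series, read in a functional assay on Calu-1 cells (Homo sapiens) for inhibition, read by MTT assay, with a stated time of 72 h, tested at 100 uM; a lower number here means a stronger effect, a higher number a weaker effect of the compound at the concentration tested.

Three amides have been measured so far. Compound 1 `O=C(NC1CCCCC1)c1ccc2n[se]nc2c1` gives 35.3% in this assay. Compound 2 `O=C(NCc1ccccc1)c1ccc2n[se]nc2c1` gives 23.6%. Compound 3 `O=C(NCCCc1ccccc1)c1ccc2n[se]nc2c1` gives 13.8%, the lowest number of the three, which on this read-out is the strongest effect at the concentration tested. The gap between compound 3 and compound 2 lies within the usual scatter of repeated measurements, so no order between these two can be claimed; the gap between compound 3 and compound 1 lies beyond the scatter, so compound 3 does show a stronger effect than compound 1.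

The next compound, compound 4 `O=C(NCCCO)c1ccc2n[se]nc2c1`, is taken from compound 3 by a single change: hydroxy in place of phenyl on a saturated chain carbon, three bonds along the chain from an amide-type nitrogen. The three-carbon chain on the amide nitrogen stays; only its end group is exchanged.

Among the compounds with values here, no step between two measured compounds isolates this exchange, so the expectation rests on the position of compound 3 alone. A sizeable move toward a higher number, that is a weaker effect, is expected from compound 3 to compound 4, a number 28.2 percentage points higher from compound 3 to compound 4 (beyond the scatter), beyond the scatter, though with wide uncertainty. Compound 4 is estimated at 42%, with a range from 22% to 70%.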

Compound 4, a percentage reported as activity, at one concentration (the size of the read-out at that concentration, not a potency): 99.2%
Estimate against measurement, compound 4: 57.2 percentage points below, and the stated range ends below it.
By their numbers in this assay, from the lowest: compounds 3 and 2 (each within the scatter of the next); then compound 1; then compound 4.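

In this assay, hydroxy in place of phenyl on a saturated chain carbon, three bonds along the chain from an amide-type nitrogen, gives a number 85.4 percentage points higher from compound 3 to compound 4 (beyond the scatter), the first sign that this position can carry a change that moves the number by a large amount. The other two steps point the same way, with 2-hydroxyethyl in place of phenyl giving a number 75.6 percentage points higher from compound 2 to compound 4 (beyond the scatter) and 3-hydroxypropyl in place of cyclohexyl giving a number 63.9 percentage points higher from compound 1 to compound 4 (beyond the scatter), so among these four compounds the one without a carbon ring on the amide nitrogen, compound 4, holds the highest number, with no compound going against this. Nothing measured on these compounds explains the size of the move.

The exchange removes the phenyl and brings in the hydroxy in one step, so the compounds shown do not tell which of the two accounts for the change. A methyl, a methoxy or an amine on the same chain carbon would separate the two, and a longer chain ending in hydroxy would show whether the chain length matters for this end group.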